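From chloro to bromo: compound 3 and compound 4

The compounds below may be only part of what the source reports. "The series", "measured", "known", "first", "only" and "open" are said of these compounds alone.

In an ADME assay on Vero cells (Chlorocebus sabaeus) for cytotoxicity, read by CellTiter-Glo and ATP content, with a stated time of 72 h (a higher number here means that more compound is tolerated, a lower number that less compound is tolerated), compound 3 `Nc1c(C2=NCCCN2)cnn1-c1cccc(Cl)c1` gives > 500000 nM, which is a limit and not a number. Compound 2 `Nc1c(C2=NCCCN2)cnn1-c1ccccc1` gives > 500000 nM, which is also a limit. Compound 3 therefore stands at the limit of > 500000 nM in this assay, at which 2 of the 3 values shown sit, so its true position is not known.

The change to compound 4 `Nc1c(C2=NCCCN2)cnn1-c1cccc(Br)c1` is bromo in place of chloro on an aromatic carbon, meta to a large group. Within the data shown here, one measured step touches this position, a step that the two limits leave unreadable from compound 2 to compound 3, where chloro takes the place of hydrogen on an aromatic carbon, and it offers no size to carry over. Compound 1 `Nc1c(C2=NCCN2)cnn1-c1cccc(Br)c1`, which also carries bromo but has a different core, gives 352000 nM, so a measurable number for compound 4 cannot be ruled out. In this assay, the expected change is an at least 1.0-fold lower number from compound 3 to compound 4 (0.01 log units; that floor lies within the scatter), and no step beyond the scatter is expected in either direction. For compound 4 the estimate is 480000 nM, with an expected range from 250000 nM to 900000 nM.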

Compound 4, half-maximal cytotoxic concentration: > 500000 nM
Compound 4 gave a limit, no number; the forecaster's own chance of this, stated with the estimate: 55%; at least 1.0-fold (0.01 log units) between middle value and limit.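

In this assay compound 4 gives only a limit, not a number, so with bromo on this aromatic carbon the six-membered core stays where hydrogen and chloro left it: the limit of > 500000 nM in this assay, at which 3 of the 4 values shown sit. The steps from compound 2 and compound 3 to compound 4 cannot be read, so nothing can be said of their size. Among these compounds, the only readable step is an at least 1.4-fold higher number from compound 1 to compound 4 (0.15 log units; that floor lies within the scatter), and it shows that bromo at this place comes with a measured number on the core of compound 1 but only a limit on the six-membered core.

From the compounds shown here alone, whether hydrogen, chloro and bromo differ at all in this assay remains open. So does whether an amine or a carboxylic acid on this aromatic carbon would bring the shared core down to a measurable number.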